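Solubility notes: aryl amide series, step to compound 4

The source may hold more compounds than are shown below. What is called first, only, known or untested is meant among the compounds shown, and "the series" means these compounds.

Measured so far:
compound 1 `COc1ccc2nc(C)cc(OCC(=O)Nc3cc(C)cc(C)c3)c2c1`, 26000 nM
compound 2 `COc1ccc2nc(C)cc(OCC(=O)Nc3cc(C)c(OC)c(C)c3)c2c1`, 17000 nM
compound 3 `COc1ccc2nc(C)cc(OCC(=O)Nc3cc(C)c(F)c(C)c3)c2c1`, 31500 nM

All three numbers come from a physicochemical assay for solubility, in phosphate buffer, measured as kinetic solubility, with a stated time of 1 h, at pH 7.4; a higher number here means a more soluble compound, a lower number a less soluble compound. Compound 3 gives the highest of the three numbers, but the step of a 1.2-fold higher number from compound 1 to compound 3 (0.08 log units; within the scatter) and the step of a 1.9-fold higher number from compound 2 to compound 3 (0.27 log units; within the scatter) are both within the scatter, so the three compounds are not separable on this assay. The step of a 1.5-fold lower number from compound 1 to compound 2 (0.18 log units; within the scatter) is likewise within the scatter.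

Compound 4 `COc1ccc2nc(C)cc(OCC(=O)Nc3ccncc3)c2c1` is the next compound. The change from compound 3 is pyridin-4-yl in place of 4-fluoro-3,5-dimethylphenyl on an amide-type nitrogen. None of the three measured steps bears directly on this change: each of them alters one substituent on the aromatic ring, whereas here the whole ring is exchanged, and all three steps stayed within the scatter. For the measured compounds named here, the measured data therefore give no direction for this step; the expectation rests on the count of what leaves and enters only. Compound 4 is estimated at 45000 nM, with a range of 15000 nM to 130000 nM. The step expected from compound 3 to compound 4 is a 1.4-fold higher number from compound 3 to compound 4 (0.15 log units; within the scatter), a modest rise that may still fall within the scatter.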

Compound 4, solubility: 91500 nM
For compound 4 the middle estimate is 2.0-fold (0.31 log units) below the measured one, and the stated range covers the measured number.
By their numbers in this assay, from the lowest: compounds 2, 1 and 3 (each within the scatter of the next); then compound 4.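

In this assay the exchange of the whole ring on the amide-type nitrogen gives a 2.9-fold higher number from compound 3 to compound 4 (0.46 log units; beyond the scatter) and also a 3.5-fold higher number from compound 1 to compound 4 (0.55 log units; beyond the scatter), whereas the substituent changes among compound 1, compound 2 and compound 3 all stayed within the scatter. This position therefore separates compounds on this read-out once pyridin-4-yl enters, although the change brings several differences at once: fewer heavy atoms, a ring hetero atom and a hydrogen-bond acceptor, with the fluoro and methyl groups gone. No measurement here identifies which of these differences accounts for the step.

Open, going by these compounds, is whether plain phenyl on the same nitrogen would give a number closer to compound 3 or to compound 4, which would separate the ring nitrogen from the loss of the substituents. Also open, on these data alone, is how a carboxylic acid or a morpholine on the ring would read in this assay.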